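Methyl for methoxy on a fused aromatic core: lipophilicity notes

This account rests on a few compounds, and the source may have more. Where it says the series, first, only, none or still open, it means among the compounds named here.

Measured compounds:
compound 1 `COc1c(OC)c(OC(=O)C(C)(C)C)c2c(OC)cccc2c1OC(=O)C(C)(C)C`, 5.6
compound 2 `COc1ccc2c(OC(C)=O)c(OC)c(OC)c(OC(C)=O)c2c1`, 2.39
compound 3 `COc1c(OC)c(OC(=O)C(C)(C)C)c2c(C)cccc2c1OC(=O)C(C)(C)C`, 6.1

In a physicochemical assay for lipophilicity (on this read-out higher numbers stand for higher lipophilicity and lower numbers for lower lipophilicity), compound 1 gives 5.6 and compound 3 gives 6.1. The change between them is methyl in place of methoxy on an aromatic carbon, and the step it made is a number 0.50 log units higher from compound 1 to compound 3 (beyond the scatter).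

Compound 2 gives 2.39 in this assay, the lowest of the three numbers. The difference between the core of compound 2 and the core of compound 1 is not broken down here.

Compound 4 `COc1c(OC)c(OC(C)=O)c2cc(C)ccc2c1OC(C)=O` is not yet measured. It differs from compound 2 by methyl in place of methoxy on an aromatic carbon. This is the same kind of change as from compound 1 to compound 3, though the place differs: there the methyl sits ortho to a fused ring and meta to a fused ring, here meta to a fused ring and para to a fused ring.

For compound 4 the step from compound 2 is expected to be about a number 0.51 log units higher from compound 2 to compound 4 (beyond the scatter), resting on the size of a number 0.50 log units higher from compound 1 to compound 3 (beyond the scatter). The estimate for compound 4 in this assay is therefore 2.9, with a likely range from 2.5 to 3.3.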

Compound 4, partition coefficient: 2.86
The estimate for compound 4 lay 0.04 log units above the measured number, within the range that was stated.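

In this assay, methyl in place of methoxy on an aromatic carbon gives a number 0.47 log units higher from compound 2 to compound 4 (beyond the scatter), in the same direction as a number 0.50 log units higher from compound 1 to compound 3 (beyond the scatter) and likewise modest, although the core and the place on it differ. The change therefore carries over between these two cores, but two pairs do not show that it would do so on any other core or at any other place. Nothing available here bears on why the step has this size.

On these data alone, whether an ethyl group, an amine or a carboxylic acid on the same aromatic carbon would fit with these steps remains open. As far as these compounds go, how the change behaves in any other read-out also remains open.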